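Swapping chloro for bromo on a shared anilide core

The source may report more compounds than this note shows. Statements on the series, on what has been measured and on what is new or still open speak of the compounds shown alone.

The study begins with compound 1 `Cc1ccc(NC(=O)C(Cl)Cl)cc1` and compound 2 `O=C(Nc1ccc(Cl)cc1)C(Cl)Cl`, which share a core and differ only in the group on the ring. In a functional assay on Bel-7402 cells (Homo sapiens) for antiproliferative activity, read by MTT assay, with a stated time of 72 h (on this read-out higher numbers stand for weaker inhibition and lower numbers for stronger inhibition), compound 1 is recorded as "not determined" (no result reported). In this assay, for the measured compounds named here, compound 2 gives 49600 nM, the only number that the study reports so far, so it is the sole point of reference. Compound 3 `O=C(Nc1ccc(Br)cc1)C(Cl)Cl` follows from compound 2 by one change: bromo in place of chloro on an aromatic carbon. Going by the values given here, with no measured step between two numbered compounds to lean on, the expected step of a 1.1-fold lower number from compound 2 to compound 3 (0.04 log units; within the scatter) is estimated to lie within the usual scatter. Compound 3 is therefore expected to give 45000 nM, in a range from 20000 nM to 100000 nM.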

Compound 3, half-maximal inhibitory concentration: 9770 nM
The estimate for compound 3 lay 4.6-fold (0.66 log units) above the measured number, and the stated range ends above it.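

Bromo in place of chloro on this aromatic carbon gives a 5.1-fold lower number from compound 2 to compound 3 (0.71 log units; beyond the scatter) in this assay and so shows that this position responds to the identity of the halogen it carries. For the compounds shown here, it is the first measured step, and it lies beyond the scatter. Nothing available explains the size or direction of this step.

Compound 1 has no number, so the methyl group offers no comparison here. As far as these compounds go, whether iodo, an amine or a methoxy group on this carbon would give a lower or higher number remains open.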